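The source may hold more compounds than are shown below. What is called first, only, known or untested is meant among the compounds shown, and "the series" means these compounds.

Measured so far in a functional assay on PC-3 cells (Homo sapiens) for inhibition, read by sulforhodamine B assay, with a stated time of 48 h; on this read-out higher numbers stand for weaker inhibition of growth and lower numbers for stronger inhibition of growth:
- compound 1 `CC1=CC[C@H](C(C)(C)NC(=S)N/N=C/c2ccccc2)CC1`: 5700 nM
- compound 2 `CC1=CC[C@H](C(C)(C)NC(=S)N/N=C/c2ccc(O)cc2)CC1`: 53800 nM
- compound 3 `CC1=CC[C@H](C(C)(C)NC(=S)N/N=C/c2cccc(Cl)c2)CC1`: 6600 nM

Compound 3 gives the second highest of the three numbers in this assay. Its nearest neighbour is compound 1, the step being a 1.2-fold higher number from compound 1 to compound 3 (0.06 log units; within the scatter), so the two are indistinguishable here. Compound 2 is the distant one: an 8.2-fold lower number from compound 2 to compound 3 (0.91 log units; beyond the scatter), a modest shift beyond the scatter.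

The next compound, compound 4 `CC1=CC[C@H](C(C)(C)NC(=S)N/N=C/c2cccc([N+](=O)[O-])c2)CC1`, differs from compound 3 in one place: nitro in place of chloro on an aromatic carbon. Going by the values given here, two measured steps bear on this. The step of a 1.2-fold higher number from compound 1 to compound 3 (0.06 log units; within the scatter) shows that putting chloro on the aromatic carbon in place of hydrogen left the number unchanged within the scatter. The step of a 9.4-fold higher number from compound 1 to compound 2 (0.97 log units; beyond the scatter) shows that hydroxy on an aromatic carbon, which brings a donor and an acceptor, moved the number upward by a modest amount. Nitro brings two acceptors and no donor; no measured compound carries it, so the direction is open. A step within the scatter, or a modest rise toward weaker inhibition, seems the likeliest outcome.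

For compound 4 the estimated value in this assay is 9000 nM, with a range from 3000 nM to 30000 nM. This corresponds to an expected step of a 1.4-fold higher number from compound 3 to compound 4 (0.13 log units; within the scatter).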

Compound 4, concentration for total growth inhibition: 88000 nM
Estimate against measurement, compound 4: 9.8-fold (0.99 log units) below; measured number above the stated range.
By their numbers in this assay, from the lowest: compounds 1 and 3 (each within the scatter of the next); then compounds 2 and 4 (each within the scatter of the next).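

With nitro, the place on the aromatic ring meta to a large group turns out not to be indifferent to substitution in this assay: a 13-fold higher number from compound 3 to compound 4 (1.12 log units; beyond the scatter) is a large step between two groups on the same carbon, whereas chloro had suggested that this place could take a substituent with no change from hydrogen. Measured directly against the unsubstituted ring, a 15-fold higher number from compound 1 to compound 4 (1.19 log units; beyond the scatter) shows that nitro, with no hydrogen-bond donor, still gives a large step toward weaker inhibition of growth, so a rise of this size on this ring does not require a donor, as the hydroxy of compound 2 might have suggested. No measurement in hand explains why nitro and chloro part so sharply at this place.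

The compounds shown do not separate the effect of the heavy atoms nitro adds from that of its hydrogen-bond acceptors, and a nitrile or a methoxy group on the same carbon would help to tell these apart. They also leave open whether an amine at this place would stay close to chloro or move with nitro.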